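The source may hold more compounds than are shown below. What is called first, only, known or untested is meant among the compounds shown, and "the series" means these compounds.

Measured compounds and their values in a functional assay on SK-MEL-2 cells (Homo sapiens) for cytotoxicity, read by sulforhodamine B assay, with a stated time of 48 h, tested at 0.1 uM; on this read-out higher numbers stand for a weaker effect at the one concentration tested and lower numbers for a stronger effect:
compound 1 `COc1cc(-c2cc(/C=C/C(=O)c3ccc(N)cc3)[nH]n2)cc(OC)c1OC`, 111%
compound 2 `COc1ccc(-c2cc(/C=C/C(=O)c3ccc(N)cc3)[nH]n2)cc1OC`, 109%
compound 3 `COc1cc(C(=O)/C=C/c2cc(-c3cc(OC)c(OC)c(OC)c3)n[nH]2)cc(OC)c1OC`, 111%

Compound 1 and compound 2 share one core and differ in a single place: hydrogen in place of methoxy on an aromatic carbon. In this assay the change gave a number 2 percentage points lower from compound 1 to compound 2 (within the scatter), so the two values show no separation that can be relied on.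

Compound 3 carries a different core, and the difference between the two cores is not broken down here. In this assay compound 3 gives 111%, which is level with compound 1 at the digits printed, and the two together stand as the highest of the three numbers; its distance from compound 2 is also within the scatter. All three measured compounds therefore sit at much the same level on this read-out.

Compound 4 `COc1ccc(-c2cc(/C=C/C(=O)c3cc(OC)c(OC)c(OC)c3)[nH]n2)cc1OC` has not yet been measured. It stands to compound 3 as compound 2 stands to compound 1: hydrogen in place of methoxy on an aromatic carbon. The place of the change is described in the same words for both pairs, so this is the same change applied to a second core.

Given that the change produced a number 2 percentage points lower from compound 1 to compound 2 (within the scatter), a step of similar size is expected from compound 3 to compound 4, namely a number 2 percentage points lower from compound 3 to compound 4 (within the scatter). Compound 4 is estimated to give 109% in this assay, with the estimate most likely lying between 99% and 119%.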

Compound 4, a percentage reported as activity, at one concentration (the size of the read-out at that concentration, not a potency): 95%
Beside the measured number, compound 4's estimate is 14 percentage points above it, outside the stated range (below it).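

In this assay the replacement of methoxy by hydrogen on an aromatic carbon gave a number 16 percentage points lower from compound 3 to compound 4 (beyond the scatter) on the core of compound 3, and this step, unlike the earlier one, is large enough to count as a real shift toward a stronger effect at the one concentration tested. Within the data shown here, this does not show that the change acts differently on the two cores, nor does it fix a single size for the change, since the series offers only two such pairs and each rests on a single reading at one concentration, which says nothing of potency. Set side by side, the two steps cannot be told apart, so the smaller step on the core of compound 1 gives no firm ground for saying that the change fails to carry over from one core to the other: the same change on two cores in this assay, a number 2 percentage points lower (within the scatter) from compound 1 to compound 2 and a number 16 percentage points lower (beyond the scatter) from compound 3 to compound 4, 14 percentage points apart, within the scatter of two such steps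

The compounds shown hold only methoxy or hydrogen at the place of the change, which leaves open how a hydroxyl group, a fluorine atom or a longer chain such as ethoxy would read there. They also leave open whether the step seen for compound 4 would persist at other concentrations or in other cell lines.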